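Hydroxy in Place of Cyano on a Weak Amide Series

A few compounds are considered here, and "the series" means these few. Any claim that something is new, unique, unknown or untested is made for them only; others in the source may bear on it.

Among the measured compounds shown here, compound 1 `Cc1ccc(-c2cc3n(n2)CCCC3)nc1` is the only member of this small set with a numerical result: in a functional assay on HEK293 cells for negative allosteric modulation of metabotropic glutamate receptor 5 (Rattus norvegicus), read by FLIPR and calcium flux, with a stated time of 170 s (on this read-out lower numbers stand for stronger inhibition and higher numbers for weaker inhibition), compound 1 gives 3000 nM. Compound 2 `N#Cc1cccnc1NC(=O)c1cc2n(n1)CCCC2` replaces the direct link of compound 1 with an amide and adds a cyano group. In this assay compound 2 is recorded as "not active" (no number reported), with no number reported, so compound 2 stands below the reach of the measurement and cannot be ranked against compound 1 on the numbers shown.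

Compound 3 `O=C(Nc1ncccc1O)c1cc2n(n1)CCCC2` is not yet measured. It differs from compound 2 in one place: hydroxy in place of cyano on an aromatic carbon. For the measured compounds named here, no step between measured compounds speaks to this change, so the size of its effect is an open question. Given that compound 2 shows "not active" (no number reported), compound 3 is expected to remain weak, with a real chance that this assay again reports no number for it. The estimate for compound 3 is 15000 nM, in a range from 3000 nM to 60000 nM.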

Compound 3, half-maximal inhibitory concentration: > 10000 nM
Compound 3 ended at the assay's limit (the forecaster's own chance of this, stated with the estimate: 55%); the middle value is on the limit's open side.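

In this assay compound 3 gives > 10000 nM, which is a limit of the assay and not a number. Among the compounds shown here, compound 2 carries no number either, and no step between compound 2 and compound 3 can be read. As far as these compounds go, how far hydroxy in place of cyano shifts inhibition stays open.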